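Swapping carbamoyl for methylsulfonyl on the amine nitrogen

The source may hold more compounds than are shown below. What is called first, only, known or untested is meant among the compounds shown, and "the series" means these compounds.

Compound 3 `CN(C[C@@H]1CCCc2cc(S(=O)(=O)c3cccc(F)c3)ccc21)C(N)=O` is the weakest binder among the three measured compounds: in an assay on isolated protein for displacement of a labelled ligand from 5-hydroxytryptamine receptor 6 (Homo sapiens) (on this read-out lower numbers stand for stronger inhibition and higher numbers for weaker inhibition), compound 3 gives 39.8 nM. Compound 1 `CNS(=O)(=O)NC[C@@H]1CCCc2cc(S(=O)(=O)c3cccc(F)c3)ccc21` gives 1 nM in this assay, and compound 2 `O=S(=O)(c1cccc(F)c1)c1ccc2c(c1)CCC[C@H]2CN1CC(O)C1` gives 0.1 nM. Both steps toward compound 3 are large, a 40-fold higher number from compound 1 to compound 3 (1.60 log units; beyond the scatter) and a 400-fold higher number from compound 2 to compound 3 (2.60 log units; beyond the scatter), so the carbamoyl(methyl)amino group is clearly the poorest of the three side groups measured.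

Compound 4 `CN(C[C@@H]1CCCc2cc(S(=O)(=O)c3cccc(F)c3)ccc21)S(C)(=O)=O` differs from compound 3 in one place: methylsulfonyl in place of carbamoyl on an amine nitrogen. Among the compounds with values here, no measured step covers this exact swap. The closest guide is compound 1, whose (methylsulfamoyl)amino group also contains a sulfonyl, and the step from it to compound 3 was a large loss, a 40-fold higher number from compound 1 to compound 3 (1.60 log units; beyond the scatter). Compound 4 brings a methylsulfonyl back into the side chain, so a return toward the stronger binding of compound 1 is expected, though probably not all the way. For compound 4 the expected step is a 13-fold lower number from compound 3 to compound 4 (1.12 log units; beyond the scatter). The estimate for compound 4 in this assay is 3 nM, with a range from 0.8 nM to 15 nM.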

Compound 4, inhibition constant: 0.398 nM
Compound 4: middle estimate off by 7.5-fold (0.88 log units), on the high side; the whole stated range lies above it.
By their numbers in this assay, from the lowest: compound 2; then compound 4; then compound 1; then compound 3.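

On the amine nitrogen, the group attached makes a very large difference: methylsulfonyl in place of carbamoyl restores binding (a 100-fold lower number from compound 3 to compound 4 (2.00 log units; beyond the scatter)), so the methyl on that nitrogen does not by itself account for the poor result of compound 3. The methyl(methylsulfonyl)amino group also edges past the (methylsulfamoyl)amino group (a 2.5-fold lower number from compound 1 to compound 4 (0.40 log units; beyond the scatter)), a modest gain that makes compound 4 better than the earlier sulfonyl-containing comparison. The 3-hydroxyazetidin-1-yl group keeps a modest lead (a 4.0-fold higher number from compound 2 to compound 4 (0.60 log units; beyond the scatter)), so the new side chain does not match the best one shown.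

On these data alone, it remains open whether an acetyl group on the same nitrogen would behave like carbamoyl or like methylsulfonyl, and whether ethylsulfonyl or phenylsulfonyl would hold the binding of methylsulfonyl. Nothing available here explains why this swap has so large an effect.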